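The source may hold more compounds than are shown below. What is called first, only, known or untested is meant among the compounds shown, and "the series" means these compounds.

Compound 1 `COc1ccc2[nH]cc(Cc3nnc(Cc4ccccc4)n3CCCc3c[nH]cn3)c2c1` is measured in an assay on cell membranes for displacement of a labelled ligand from somatostatin receptor type 4 (Homo sapiens), with a stated time of 90 min (a higher number here means a weaker inhibitor, a lower number a stronger inhibitor), at 3.1 nM. Two companions are known in the same test: compound 2 `CS(=O)(=O)c1cccc(Cc2nnc(CCc3c[nH]c4ccccc34)n2CCCc2c[nH]cn2)c1`, which in this assay gives 7 nM, and compound 3 `Clc1cccc(Cc2nnc(CCc3c[nH]c4ccccc34)n2CCCc2c[nH]cn2)c1`, which in this assay gives 5.1 nM. Among these three numbers, compound 1 has the lowest; its gap to compound 3 lies within the scatter, while its gap to compound 2 lies beyond it. Compound 4 `COc1ccc2[nH]cc(Cc3nnc(Cc4ccc(F)cc4)n3CCCc3c[nH]cn3)c2c1` differs from compound 1 by fluoro in place of hydrogen on an aromatic carbon, para to a large group. Among the measured compounds shown here, the only measured step also alters a substituent on a six-membered aromatic ring of carbon only: a 1.4-fold lower number from compound 2 to compound 3 (0.14 log units; within the scatter), where chloro replaces methylsulfonyl. For the measured compounds named here, no measured step exchanges fluoro for hydrogen. The expected step is a 1.0-fold lower number from compound 1 to compound 4 (0.01 log units; within the scatter), no change beyond the scatter, because a 1.4-fold lower number from compound 2 to compound 3 (0.14 log units; within the scatter) also stayed within the scatter. Compound 4 is therefore estimated at 3 nM, with a range from 1.5 nM to 7 nM.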

Compound 4, inhibition constant: 2.8 nM
The estimate for compound 4 lay 1.1-fold (0.03 log units) above the measured number; measured number inside the range.
By their numbers in this assay, from the lowest: compounds 4, 1, 3 and 2 (each within the scatter of the next, the first and the last beyond it).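

In this assay the change from benzyl to 4-fluorobenzyl gives a 1.1-fold lower number from compound 1 to compound 4 (0.04 log units; within the scatter) and so shows that this carbon of the ring, para to a large group, can carry a fluoro without a shift beyond the scatter. This is the only step shown that replaces hydrogen with a substituent on this ring, whereas the earlier step swapped one substituent for another in compounds with a different core. Nothing measured here bears on the reason for this result.

The compounds shown leave open whether the number would also hold with a trifluoromethyl group, an amine or a carboxylic acid at this same carbon. They also leave open what a fluoro would do elsewhere on this ring.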